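Butyl in Place of Benzyl: What to Expect for Compound 3

The source may hold more compounds than are shown below. What is called first, only, known or untested is meant among the compounds shown, and "the series" means these compounds.

compound 1 `CCCCn1cnc2c(Nc3ccccc3)nc(NCOCc3ccc(/C=C/C(=O)Nc4ccccc4N)cc3)nc21`: 23.1%
compound 2 `Nc1ccccc1NC(=O)c1ccc(CNc2nc(Cl)nc3c2ncn3Cc2ccccc2)cc1`: 43.8%

Going by the values given here, in a functional assay on NCI-H460 cells (Homo sapiens) for antiproliferative activity, read by CCK-8 assay, with a stated time of 72 h, tested at 2 uM (on this read-out higher numbers stand for a stronger effect at the one concentration tested and lower numbers for a weaker effect), compound 2 gives 43.8%, the higher of the two numbers measured so far. Compound 1 gives 23.1% in the same test, a gap that lies beyond the usual scatter. Compound 3 `CCCCn1cnc2c(NCc3ccc(C(=O)Nc4ccccc4N)cc3)nc(Cl)nc21` differs from compound 2 by propyl in place of phenyl on a saturated chain carbon bound to an aromatic nitrogen. Among the compounds with values here, no measured pair isolates this change, so its size is uncertain. A modest loss in this assay, perhaps not beyond the scatter, is expected, a number 8.8 percentage points lower from compound 2 to compound 3 (within the scatter). Compound 3 is estimated at 35%, with a likely range from 18% to 52%.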

Compound 3, a percentage reported as inhibition, at one concentration (the size of the read-out at that concentration, not a potency): 19.7%
Compound 3: the middle estimate sits 15.3 percentage points above what was measured; the measured number falls inside the stated range.
By their numbers in this assay, from the lowest: compounds 3 and 1 (each within the scatter of the next); then compound 2.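

Propyl in place of phenyl on a saturated chain carbon bound to an aromatic nitrogen gives a number 24.1 percentage points lower from compound 2 to compound 3 (beyond the scatter) in this assay with the rest of the structure unchanged. Going by these compounds alone, this is the first single-place step, and it shows that this position is not indifferent to the group it carries: here benzyl serves better than butyl. Nothing measured here explains why the number falls.

This one step cannot separate the loss of the aromatic ring from the change to a smaller group. As far as these compounds go, how a cyclohexyl ring, a pyridine ring or a longer chain would fare at this position stays open.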